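Bromo to Trifluoromethyl Beside the Phenol Hydroxy Group

This account rests on a few compounds, and the source may have more. Where it says the series, first, only, none or still open, it means among the compounds named here.

Compound 3 `CCC/N=C1\S/C(=C\c2ccc(O)c(Br)c2)C(=O)N1c1ccccc1C` is the compound to watch here. In a physicochemical assay for lipophilicity, read by HPLC, at pH 7.4 (on this read-out higher numbers stand for higher lipophilicity and lower numbers for lower lipophilicity), compound 3 gives 3.9, the highest of the three measured values. Compound 1 `Cc1ccccc1N1C(=O)/C(=C/c2ccc(O)c(Cl)c2)S/C1=N\CCCF` gives 3.4 in this assay, and compound 2 `CCC/N=C1\S/C(=C\c2ccc(O)c(Cl)c2)C(=O)N1C1CC1` gives 3.4; each of these stands lower than compound 3 by a margin beyond the scatter. Compound 4 `CCC/N=C1\S/C(=C\c2ccc(O)c(C(F)(F)F)c2)C(=O)N1c1ccccc1C` keeps everything in compound 3 except one group on an aromatic carbon, ortho to a hydroxy group: trifluoromethyl in place of bromo on an aromatic carbon. For the measured compounds named here, no measured pair shows this exact change, so the step can only be expected, not read off. The step of a number 0.10 log units higher from compound 3 to compound 4 (within the scatter) is expected to stay within the scatter, with no clear direction. Compound 4 is therefore estimated at 4 in this assay, between 3.6 and 4.4.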

Compound 4, distribution coefficient: 3.8
The estimate for compound 4 lay 0.20 log units above the measured number; measured number inside the range.
By their numbers in this assay, from the lowest: compounds 1 and 2 (each within the scatter of the next); then compounds 4 and 3 (each within the scatter of the next).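

In this assay, trifluoromethyl in place of bromo on an aromatic carbon ortho to a hydroxy group gives a number 0.10 log units lower from compound 3 to compound 4 (within the scatter), so this read-out does not tell the two groups apart at this position. The earlier compounds held no pair differing only here, which makes this the only such step shown. As far as these compounds go, whether an amine or a carboxylic acid on this same carbon would also stay within the scatter of compound 3 remains open. No measurement shown speaks to what lies behind this result.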